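The source may hold more compounds than are shown below. What is called first, only, known or untested is meant among the compounds shown, and "the series" means these compounds.

Compound 1 `Cc1cc(C(=O)c2ccccc2)ccc1OCC(=O)Nc1nc(-c2ccccc2)cs1`: in a functional assay on Ehrlich cells (Mus musculus) for cytotoxicity, read by MTT assay, with a stated time of 48 h (a higher number here means a weaker inhibitor, a lower number a stronger inhibitor), compound 1 gives 24000 nM.
Compound 2 `COc1ccc(-c2csc(NC(=O)COc3ccc(C(=O)c4ccccc4)cc3C)n2)cc1`: compound 2 gives 28400 nM.
Compound 3 `Cc1ccc(C(=O)c2ccc(OCC(=O)Nc3nc(-c4ccccc4)cs3)c(C)c2)cc1`: compound 3 gives 29900 nM.

The number for compound 3 differs from those of compound 1 and compound 2 only within the usual scatter, so the three compounds cannot be told apart in this assay. Compound 4 `COc1ccc(-c2csc(NC(=O)COc3ccc(C(=O)c4ccc(C)cc4)cc3C)n2)cc1` arises from compound 3 by methoxy in place of hydrogen on an aromatic carbon. The same change has been seen once before: a 1.2-fold higher number from compound 1 to compound 2 (0.07 log units; within the scatter), a step within the scatter. Likewise a 1.2-fold higher number from compound 1 to compound 3 (0.10 log units; within the scatter) shows that the methyl already present in compound 3 made no difference beyond the scatter. Combining the two changes is therefore expected to give a 1.0-fold higher number from compound 3 to compound 4 (0.02 log units; within the scatter), no shift beyond the scatter. For compound 4 the estimated value is 31000 nM, in the expected range 15000 nM to 65000 nM.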

Compound 4, half-maximal inhibitory concentration: 20700 nM
Estimate against measurement, compound 4: 1.5-fold (0.18 log units) above, within the range that was stated.
By their numbers in this assay, from the lowest: compounds 4, 1, 2 and 3 (each within the scatter of the next).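

In this assay, methoxy in place of hydrogen gives a 1.4-fold lower number from compound 3 to compound 4 (0.16 log units; within the scatter), and methyl in place of hydrogen gives a 1.4-fold lower number from compound 2 to compound 4 (0.14 log units; within the scatter), so neither change moves the number beyond the scatter on this second core. The methoxy change reads alike on both cores: the same change on two cores in this assay, a 1.2-fold higher number (0.07 log units; within the scatter) from compound 1 to compound 2 and a 1.4-fold lower number (0.16 log units; within the scatter) from compound 3 to compound 4, 1.7-fold (0.23 log units) apart, within the scatter of two such steps. The methyl change does too: the same change on two cores in this assay, a 1.2-fold higher number (0.10 log units; within the scatter) from compound 1 to compound 3 and a 1.4-fold lower number (0.14 log units; within the scatter) from compound 2 to compound 4, 1.7-fold (0.23 log units) apart, within the scatter of two such steps.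

As far as these compounds go, every compound here stays within the scatter of the others, so what would shift this number remains open. An amine or a carboxylic acid on the same aromatic carbon, or a longer chain in place of the methoxy, might behave differently.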